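This account rests on a few compounds, and the source may have more. Where it says the series, first, only, none or still open, it means among the compounds named here.

Of the two numbers shown, compound 2 `Nc1nc(N/N=C/c2ccc[nH]2)nc2c1ncn2[C@@H]1O[C@H](CO)[C@@H](O)[C@H]1O` has the higher in an assay on CHO-K1 cells for displacement of a labelled ligand from adenosine receptor A1 (Homo sapiens), read by scintillation counting, with a stated time of 60 min (on this read-out lower numbers stand for stronger inhibition and higher numbers for weaker inhibition), where compound 2 gives 8 nM while compound 1 `COc1ccc(/C=N/Nc2nc(N)c3ncn([C@@H]4O[C@H](CO)[C@@H](O)[C@H]4O)c3n2)cn1` gives 2.6 nM. Compound 3 `CCCOc1ccc(/C=N/Nc2nc(N)c3ncn([C@@H]4O[C@H](CO)[C@@H](O)[C@H]4O)c3n2)cc1` differs from compound 2 by 4-propoxyphenyl in place of 1H-pyrrol-2-yl on a carbon with a double bond to nitrogen, a six-membered aromatic ring taking the place of the five-membered aromatic ring. For the measured compounds named here, the one measured step that bears on this, a 3.1-fold higher number from compound 1 to compound 2 (0.49 log units; beyond the scatter), went from a six-membered aromatic ring to the five-membered one, so a reversal of roughly that size, a lower number, is expected here. For compound 3 the expected step is a 2.7-fold lower number from compound 2 to compound 3 (0.43 log units; beyond the scatter), with an estimate of 3 nM, between 1 nM and 10 nM.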

Compound 3, inhibition constant: > 10000 nM
Compound 3: only a limit was reported; the forecaster's own chance of this, stated with the estimate: 2%; middle value at least 3300-fold (3.52 log units) from the limit.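

In this assay compound 3 stands at a limit of the assay, not at a number: the limit of > 10000 nM in this assay, at which 1 of the 3 values shown sits. This position, on a carbon with a double bond to nitrogen, does not accept every six-membered aromatic ring: 4-propoxyphenyl brings an at least 1200-fold higher number from compound 2 to compound 3 (3.09 log units; beyond the scatter), and also an at least 3800-fold higher number from compound 1 to compound 3 (3.58 log units; beyond the scatter). Compound 1 carries a six-membered aromatic ring as well, so ring size alone does not decide the result here. The compounds shown leave open whether the propyl chain accounts for this loss, and whether 4-methoxyphenyl or 4-hydroxyphenyl on the same carbon would keep the binding of compound 1.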